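The source may hold more compounds than are shown below. What is called first, only, known or untested is meant among the compounds shown, and "the series" means these compounds.

Three compounds share one core and differ only in the chain that hangs from the aromatic oxygen. Compound 1 (`NCCCCCCOc1ccc2c(=O)c(-c3ccc(O)cc3)coc2c1`) carries an amine at the chain end and in an assay (Cricetulus griseus) for inhibition of aldehyde dehydrogenase, mitochondrial (Homo sapiens) (a higher number here means a weaker inhibitor, a lower number a stronger inhibitor), compound 1 gives 100 nM. Compound 2 (`CCOC(=O)CCCCCOc1ccc2c(=O)c(-c3ccc(O)cc3)coc2c1`) ends in an ester, and in this assay compound 2 gives 280 nM. Compound 3 (`O=C(O)CCCCCCCCCCCOc1ccc2c(=O)c(-c3ccc(O)cc3)coc2c1`) ends in a carboxylic acid on a longer chain, and in this assay compound 3 gives 130 nM. Among these three numbers compound 3 stands second highest, close to compound 1 and further from compound 2.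

Compound 4 (`O=C(O)CCCCCCCCCOc1ccc2c(=O)c(-c3ccc(O)cc3)coc2c1`) shortens the chain of compound 3: carboxy in place of 2-carboxyethyl on a saturated chain carbon, nine bonds along the chain from an oxygen on an aromatic ring. Among the measured compounds shown here, no measured step changes the chain length while keeping the acid end, so the closest guides are the steps that alter the chain terminus. From compound 1 to compound 3 the number moved a 1.3-fold higher number from compound 1 to compound 3 (0.11 log units; within the scatter), while from compound 2 to compound 3 it moved a 2.2-fold lower number from compound 2 to compound 3 (0.33 log units; beyond the scatter). Both are small, suggesting this assay tolerates variation in the chain, so compound 4 is expected to sit near compound 3, with the step from compound 3 to compound 4 estimated as a 1.1-fold higher number from compound 3 to compound 4 (0.03 log units; within the scatter). Compound 4 is therefore estimated at 140 nM, within a range of 70 nM to 300 nM.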

Compound 4, half-maximal inhibitory concentration: 50 nM
The estimate for compound 4 lay 2.8-fold (0.45 log units) above the measured number; the whole stated range lies above it.
By their numbers in this assay, from the lowest: compounds 4, 1 and 3 (each within the scatter of the next, the first and the last beyond it); then compound 2.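

With the acid end kept in place, the chain length itself now shows an effect in this assay: carboxy in place of 2-carboxyethyl, nine bonds along the chain from an oxygen on an aromatic ring, gives a 2.6-fold lower number from compound 3 to compound 4 (0.41 log units; beyond the scatter), so the earlier impression of a tolerant chain does not hold for this change. The shorter acid also stands well apart from the ester, with a 5.6-fold lower number from compound 2 to compound 4 (0.75 log units; beyond the scatter), whereas a 2.0-fold lower number from compound 1 to compound 4 (0.30 log units; within the scatter) leaves the amine and the shorter acid unranked, since that step stays within the scatter. Nothing at hand explains why the shorter acid chain gives the lower number.

Among the compounds shown here, only two chain lengths carry the carboxylic acid here, so it remains open whether a carboxylic acid on a still shorter chain, or on a chain of intermediate length, would follow the same direction. On these data alone, it is equally open whether an amine or an ethyl ester would respond to chain length in the same way as the carboxylic acid does, given that each of those ends appears on a single chain only.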